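Notes on compound 4: bromo in place of trifluoromethyl

A few compounds are considered here, and "the series" means these few. Any claim that something is new, unique, unknown or untested is made for them only; others in the source may bear on it.

Measured so far:
Compound 1, `Cc1cccc(NNS(=O)(=O)c2ccc(S(C)(=O)=O)cc2)c1`: in an assay on HeLa cells for inhibition of Indoleamine 2,3-dioxygenase 1 (Homo sapiens), read by spectrophotometry, with a stated time of 24 h (a lower number here means that less compound is needed, a higher number that more compound is needed for the effect), compound 1 gives 7850 nM.
Compound 2, `COc1ccc(NNS(=O)(=O)c2ccc(NC(C)=O)cc2)cc1`: in this assay compound 2 gives > 10000 nM, which is a limit of the assay and not a number.
Compound 3, `CC(=O)Nc1ccc(S(=O)(=O)NNc2ccc(C(F)(F)F)cc2)cc1`: in this assay compound 3 gives 181 nM.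

Compound 3 holds the lowest of the two numbers measured; compound 1 stands well above it, beyond the scatter, and compound 2 sits at the limit (the limit of > 10000 nM in this assay, at which 1 of the 3 values shown sits).

Compound 4, `CC(=O)Nc1ccc(S(=O)(=O)NNc2ccc(Br)cc2)cc1`, has not been measured. It differs from compound 3 by bromo in place of trifluoromethyl on an aromatic carbon.

Among the measured compounds shown here, only one measured step touches this position: an at least 55-fold lower number from compound 2 to compound 3 (1.74 log units; beyond the scatter), which shows that the group there can move the number a great deal. For the measured compounds named here, no measured pair compares bromo with trifluoromethyl, so the direction for compound 4 is uncertain. Compound 4 is expected to stay in the same broad region as compound 3, and for compound 4 a value of 400 nM is estimated, within 120 nM to 1500 nM. This estimate means a step of a 2.2-fold higher number from compound 3 to compound 4 (0.34 log units; beyond the scatter), expected to be modest and possibly within the scatter.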

Compound 4, half-maximal effective concentration: 85 nM
Compound 4: the middle estimate sits 4.7-fold (0.67 log units) above what was measured, and the stated range ends above it.
By their numbers in this assay, from the lowest: compound 4; then compound 3; then compound 1. At a limit, above all of these: compound 2.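

In this assay, bromo in place of trifluoromethyl gives a 2.1-fold lower number from compound 3 to compound 4 (0.33 log units; beyond the scatter), so a single bromine atom at this position serves at least as well as the four heavy atoms of trifluoromethyl, and the position is not tied to that one group. Set against methoxy, bromo gives an at least 110-fold lower number from compound 2 to compound 4 (2.07 log units; beyond the scatter), a second replacement of methoxy that lowers the number by a large step. Compound 2 carries a limit of the assay and not a number, so both steps from it give only a minimum size: the limit of > 10000 nM in this assay, at which 1 of the 4 values shown sits.

As far as these compounds go, how chloro, iodo, an amine or a carboxylic acid would compare at this position stays open. Also open, from the compounds shown here alone, is whether the order of bromo, trifluoromethyl and methoxy holds when the rest of the core changes.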